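Adding a dimethylamino group to the benzyl arm

The compounds below may be only part of what the source reports. "The series", "measured", "known", "first", "only" and "open" are said of these compounds alone.

Compound 1 `O=C(Nc1c(F)cc(F)cc1F)N(Cc1cccc(-c2cc[nH]n2)c1)C1CCCCCC1`, compound 2 `Cc1cc(C)c(NC(=O)N(Cc2ccccc2)Cc2cccc(-c3cc[nH]n3)c2)c(C)c1` and compound 3 `O=C(Nc1c(F)cc(F)cc1F)N(Cc1ccccc1)Cc1cccc(-c2cc[nH]n2)c1` share one core and differ at the groups on its amide-type nitrogens. In a functional assay on a cell-free system (plasma) with sterol O-acyltransferase, Soat (Rattus norvegicus) as the target (on this read-out lower numbers stand for an effect already at smaller amounts and higher numbers for an effect only at larger amounts of compound), compound 1 gives 0.062 mg/kg and compound 3 gives 0.096 mg/kg, two numbers within the scatter of each other, as a 1.5-fold higher number from compound 1 to compound 3 (0.19 log units; within the scatter) shows. Compound 2 reaches only the limit of > 1 mg/kg in this assay. Compound 4 `CN(C)c1ccc(CN(Cc2cccc(-c3cc[nH]n3)c2)C(=O)Nc2c(F)cc(F)cc2F)cc1` is compound 3 with dimethylamino in place of hydrogen on an aromatic carbon. Of the measured steps, a 1.5-fold higher number from compound 1 to compound 3 (0.19 log units; within the scatter) changes the same nitrogen arm and hardly moves the number, while an at least 10-fold lower number from compound 2 to compound 3 (1.01 log units; beyond the scatter) changes the other arm. Neither tests a group on the benzyl ring, so no step beyond the scatter is expected, a 1.0-fold higher number from compound 3 to compound 4 (0.02 log units; within the scatter). Compound 4 is therefore estimated at 0.1 mg/kg, between 0.03 mg/kg and 0.4 mg/kg.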

Compound 4, dose for half-maximal effect: < 0.32 mg/kg
Compound 4: only a limit was reported (the forecaster's own chance of this, stated with the estimate: 10%); the middle value does not contradict the limit.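

Compound 4 carries only a limit, so its steps from compound 3 and from compound 1 cannot be read: the limit of < 0.32 mg/kg in this assay, at which 1 of the 4 values shown sits. As far as these compounds go, how far the dimethylamino group shifts compound 4 from compound 3 stays open.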